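Halogen swap on the indole core: ester ketones versus methylene analogues

This account rests on a few compounds, and the source may have more. Where it says the series, first, only, none or still open, it means among the compounds named here.

Compound 1 `CCOC(=O)c1[nH]c2ccc(Cl)cc2c1C(=O)c1cc(OC)c(OC)c(OC)c1N` and compound 2 `CCOC(=O)c1[nH]c2ccc(Br)cc2c1C(=O)c1cc(OC)c(OC)c(OC)c1N` share one core; compound 3 `COc1cc(Cc2c[nH]c3ccc(Cl)cc23)c(N)c(OC)c1OC` and compound 4 `COc1cc(Cc2c[nH]c3ccc(Br)cc23)c(N)c(OC)c1OC` share another, and the difference between the two cores is not broken down here. In a functional assay on HT-29 cells (Homo sapiens) for cytotoxicity, read by sulforhodamine B assay, with a stated time of 48 h (a higher number here means a weaker inhibitor of growth, a lower number a stronger inhibitor of growth), compound 1 gives 6840 nM and compound 2 gives 5380 nM. The change bromo in place of chloro on an aromatic carbon gave a 1.3-fold lower number from compound 1 to compound 2 (0.10 log units; within the scatter). In this assay compound 3 gives "not active" (no number reported), with no number reported. The change bromo in place of chloro on an aromatic carbon is the same change, made at the same place, on the second core. Since the step from compound 1 to compound 2 stayed within the scatter, compound 4 is expected to behave like compound 3 and most likely to return a limit rather than a number. Compound 4 is estimated at 60000 nM, with a range from 15000 nM to 250000 nM.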

Compound 4, concentration for 50% growth inhibition: "not active" (no number reported)
The entry for compound 4 holds no number, and the estimate cannot be compared.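

In this assay neither compound 3 nor compound 4 returns a number, so no step can be read between them. On these data alone, what bromo in place of chloro does on this core remains open. No supporting evidence bears on this result.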